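Trimming a sulfonamide substituent in a growth-inhibition series

A few compounds are considered here, and "the series" means these few. Any claim that something is new, unique, unknown or untested is made for them only; others in the source may bear on it.

Measured compounds:
Compound 1, `CCC1C(=O)N(C)c2cnc(-n3ccc4cc(C(N)=O)ccc43)nc2N1c1ccn(C)n1`, in a functional assay on NCI-H1975 cells (Homo sapiens) for antiproliferative activity, read by CCK-8 assay, with a stated time of 72 h (a higher number here means a weaker inhibitor of growth, a lower number a stronger inhibitor of growth), reported as "not active" (no number reported).
Compound 2, `CC[C@@H]1C(=O)N(C)c2cnc(Nc3ccc(S(=O)(=O)NC4CCCC4)cc3)nc2N1C1CCCC1`, in this assay gives 1710 nM.
Compound 3, `CCCNS(=O)(=O)c1ccc(Nc2ncc3c(n2)N(c2ccn(C)n2)C(CC)C(=O)N3C)cc1`, in this assay gives 21700 nM.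

Three compounds share a common core and differ in the groups hanging from it. Compound 1 gave no number in this assay, only the report that it was not active. Of the two compounds with a number, compound 2 stands lowest, meaning it is the stronger inhibitor of growth; compound 3 lies well above it, a gap beyond the usual scatter. Compound 3 differs from compound 2 in more than one place, so no single change can be tied to that gap.

Compound 4, `CC[C@@H]1C(=O)N(C)c2cnc(Nc3ccc(S(=O)(=O)NC)cc3)nc2N1C1CCCC1`, has not been measured. It differs from compound 2 in one spot: methyl in place of cyclopentyl on a sulfonamide nitrogen. For the measured compounds named here, no measured pair isolates this kind of change, so the expected step is uncertain. A modest weakening is expected, with the estimated step from compound 2 to compound 4 being a 2.3-fold higher number from compound 2 to compound 4 (0.37 log units; beyond the scatter), small enough that it may sit close to the scatter. Compound 4 is therefore estimated at 4000 nM, within a range of 1500 nM to 12000 nM.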

Compound 4, concentration for 50% growth inhibition: 1410 nM
For compound 4 the middle estimate is 2.8-fold (0.45 log units) above the measured one; measured number below the stated range.
By their numbers in this assay, from the lowest: compounds 4 and 2 (each within the scatter of the next); then compound 3.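

In this assay, putting methyl in place of cyclopentyl on the sulfonamide nitrogen gives a 1.2-fold lower number from compound 2 to compound 4 (0.08 log units; within the scatter), so compound 2 and compound 4 cannot be told apart at this level of growth inhibition. For the compounds shown here, this is the first pair that isolates a single place, and it shows that, with the rest of the molecule held fixed, the five-membered carbon ring on this nitrogen is not needed to keep the activity of compound 2, since a single methyl serves equally well. No measurement available here explains why the two groups give matching results.

Going by these compounds alone, only two groups on this nitrogen can be compared directly, so it remains open whether the same level would hold with a bare sulfonamide carrying only hydrogen, or with a group bearing an amine or a carboxylic acid. Compound 3, which carries a propyl group on this nitrogen, differs from both compound 2 and compound 4 in more than one place, so its propyl group cannot be judged on its own, and the source of its gap to them stays unresolved.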